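A few compounds are considered here, and "the series" means these few. Any claim that something is new, unique, unknown or untested is made for them only; others in the source may bear on it.

Measured so far:
Compound 1 `CCCCCCNC(=O)n1cc(F)c(=O)n(CC)c1=O`: in an assay on HEK293 cells for inhibition of acid ceramidase (Rattus norvegicus), read by LC-MS, with a stated time of 30 min (on this read-out lower numbers stand for stronger inhibition and higher numbers for weaker inhibition), compound 1 gives 18 nM.
Compound 2 `CCCCCCNC(=O)n1cc(F)c(=O)n(C(=O)C(C)C)c1=O`: in this assay compound 2 gives 21 nM.

Compound 2 stands with the higher of the two numbers, but its neighbour compound 1 sits close: the step of a 1.2-fold higher number from compound 1 to compound 2 (0.07 log units; within the scatter) is within the scatter, so the two compounds cannot be ordered. Compound 3 `CCCCCCNC(=O)n1cc(F)c(=O)n(C(=O)OCC)c1=O` has not yet been measured. It differs from compound 2 in one place: ethoxy in place of isopropyl on a carbonyl carbon. Within the data shown here, only the step from compound 1 to compound 2 bears on this change, and it replaced ethyl on the aromatic nitrogen with isopropylcarbonyl without moving the number beyond the scatter. Exchanging isopropyl for ethoxy on that carbonyl carbon is therefore expected to leave this assay largely unchanged, with no step beyond the scatter in either direction; the expected step is a 1.2-fold higher number from compound 2 to compound 3 (0.08 log units; within the scatter). Compound 3 is estimated at 25 nM, with a range from 8 nM to 80 nM.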

Compound 3, half-maximal inhibitory concentration: 12 nM
Compound 3: middle estimate off by 2.1-fold (0.32 log units), on the high side; the range from low to high includes it.
By their numbers in this assay, from the lowest: compounds 3, 1 and 2 (each within the scatter of the next).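

In this assay, ethoxy in place of isopropyl on a carbonyl carbon gives a 1.8-fold lower number from compound 2 to compound 3 (0.24 log units; within the scatter) and thus shows that a group with one hydrogen-bond acceptor can enter at this place without separating the two compounds. Ethoxycarbonyl in place of ethyl on an aromatic nitrogen gives a 1.5-fold lower number from compound 1 to compound 3 (0.18 log units; within the scatter) as well, so ethyl, isopropylcarbonyl and ethoxycarbonyl on that nitrogen all give numbers that cannot be ordered. Nothing at hand explains why these exchanges leave the numbers so close.

The compounds shown leave open whether an amine on the carbonyl carbon, or a longer chain in place of ethoxy, would keep the number within this narrow band. The rest of the structure is the same in all three compounds, so they say nothing about changes elsewhere.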